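Swapping the halogenated ring for a second methoxyphenyl

The compounds below may be only part of what the source reports. "The series", "measured", "known", "first", "only" and "open" are said of these compounds alone.

Compound 2 `C=CCn1c(=O)/c(=C\c2cc(Br)ccc2F)[nH]c(=O)/c1=C\c1ccccc1OC` has no single number to stand on: in a functional assay on A549 cells (Homo sapiens) for cytotoxicity, read by CCK-8 assay, with a stated time of 72 h (on this read-out higher numbers stand for weaker inhibition and lower numbers for stronger inhibition), compound 2 gives "not active" (no number reported). Its relative compound 1 `C=CCn1c(=O)/c(=C\c2cccc(F)c2)[nH]c(=O)/c1=C\c1ccccc1OC` does give a number, and in this assay compound 1 gives 19700 nM. Compound 3 `C=CCn1c(=O)/c(=C\c2ccccc2OC)[nH]c(=O)/c1=C\c1ccccc1OC` arises from compound 2 by 2-methoxyphenyl in place of 5-bromo-2-fluorophenyl on a double-bonded chain carbon bound to an aromatic carbon. Going by the values given here, with no measured step from compound 2, a step cannot be sized against it; the change is expected to move the read-out in this assay downward, toward the region where compound 1 stands, if at all. For compound 3 the expected value is 25000 nM, within 8000 nM to 80000 nM.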

Compound 3, half-maximal inhibitory concentration: 22400 nM
Compound 3: the middle estimate sits 1.1-fold (0.05 log units) above what was measured; low and high end bracket the measured number.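

The step shows a 1.1-fold higher number from compound 1 to compound 3 (0.06 log units; within the scatter) in this assay, so at this place 2-methoxyphenyl and 3-fluorophenyl read alike, with compound 3 giving a number as compound 1 does. Compound 2, carrying 5-bromo-2-fluorophenyl, has no number, so any step to or from it cannot be read. Nothing measured here bears on why these compounds read as they do. On these data alone, what stays open is whether a phenyl ring carrying an amine or a carboxylic acid at this place would read differently in this assay and give a clearly lower number.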